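This account rests on a few compounds, and the source may have more. Where it says the series, first, only, none or still open, it means among the compounds named here.

In a functional assay on PC-3 cells (Homo sapiens) for cytotoxicity, read by sulforhodamine B assay, with a stated time of 48 h (on this read-out higher numbers stand for weaker inhibition and lower numbers for stronger inhibition), compound 1 `C[C@H]1CC[C@@H]2[C@@H](OC(=O)[C@]23CC(c2c(Cl)cccc2Cl)=NO3)[C@]2(C)C(=O)C=C[C@@]12O` gives 56000 nM. Among the measured compounds shown here, compound 2 `COc1ccc(C2=NO[C@]3(C2)C(=O)O[C@@H]2[C@H]3CC[C@H](C)[C@]3(O)C=CC(=O)[C@@]23C)cc1` gives 35000 nM, which lies within the scatter of compound 1, the only other measured number. Compound 3 `C[C@H]1CC[C@@H]2[C@@H](OC(=O)[C@]23CC(c2ccc(Cl)cc2)=NO3)[C@]2(C)C(=O)C=C[C@@]12O` differs from compound 2 as follows: chloro in place of methoxy on an aromatic carbon. For the measured compounds named here, the only measured step that bears on this also exchanges the aromatic group: a 1.6-fold lower number from compound 1 to compound 2 (0.20 log units; within the scatter). The step expected in this assay is therefore none beyond the scatter, with a 1.1-fold higher number from compound 2 to compound 3 (0.06 log units; within the scatter) estimated. For compound 3 the estimated value is 40000 nM, with a range of 18000 nM to 90000 nM.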

Compound 3, half-maximal inhibitory concentration: 49000 nM
Compound 3: the middle estimate sits 1.2-fold (0.09 log units) below what was measured; measured number inside the range.
By their numbers in this assay, from the lowest: compounds 2, 3 and 1 (each within the scatter of the next).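

In this assay, chloro in place of methoxy on an aromatic carbon, para to a large group, gives a step within the scatter (a 1.4-fold higher number from compound 2 to compound 3 (0.15 log units; within the scatter)). The change from 2,6-dichlorophenyl to 4-chlorophenyl also stays within the scatter (a 1.1-fold lower number from compound 1 to compound 3 (0.06 log units; within the scatter)), so the three aromatic groups shown are not separated on this read-out. No available evidence bears on this result.

Open, on these data alone, is whether an amine or a carboxylic acid on this aromatic ring would give a step beyond the scatter. Also open, as far as these compounds go, is whether a longer alkyl chain in place of the aromatic ring would do so.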